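Swapping a Hydroxyphenyl for a Fluorophenyl: What to Expect

A few compounds are considered here, and "the series" means these few. Any claim that something is new, unique, unknown or untested is made for them only; others in the source may bear on it.

Of the compounds shown here, three have been measured in a functional assay on HT-29 cells (Homo sapiens) for inhibition, read by MTT assay, tested at 100 uM; on this read-out higher numbers stand for more inhibition at the one concentration tested (going by the name of the read-out) and lower numbers for less inhibition. Compound 1, `Oc1cccc(Nc2nc(NCc3ccccc3)c3ccccc3n2)c1`, gives 81.9% in this assay. Compound 2, `COc1ccccc1N/N=C1/C(=O)N(C(N)=S)N=C1c1ccccc1`, gives 38%. Compound 3, `CCC(C)(C)c1ccc(O)c(NS(=O)(=O)c2ccccc2OC(F)(F)F)c1`, gives 37.5%. Compound 1 therefore stands highest of the three numbers; its nearest neighbour is compound 2, and both that gap and the larger gap to compound 3 lie beyond the usual scatter of repeated measurements, so compound 1 shows the highest inhibition in this assay of the three.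

Compound 4, `Fc1ccc(Nc2nc(NCc3ccccc3)c3ccccc3n2)cc1`, has not yet been measured. It differs from compound 1 in a single place: 4-fluorophenyl in place of 3-hydroxyphenyl on a nitrogen on an aromatic ring. The group that leaves carries one hydrogen-bond donor and one hydrogen-bond acceptor; the group that enters carries neither. Among the measured compounds shown here, no pair of measured compounds differing in only one place is available, so the size of this step cannot be read from the data and must be judged from the change itself. Because compound 1 reaches 81.9%, there is room to fall, and a moderate drop is expected, a number 16.9 percentage points lower from compound 1 to compound 4 (beyond the scatter). Compound 4 is estimated at 65%, with a likely range from 35% to 90%.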

Compound 4, a percentage reported as inhibition, at one concentration (the size of the read-out at that concentration, not a potency): 93.4%
Compound 4: middle estimate off by 28.4 percentage points, on the low side, outside the stated range (above it).
By their numbers in this assay, from the lowest: compounds 3 and 2 (each within the scatter of the next); then compound 1; then compound 4.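

In this assay, putting 4-fluorophenyl in place of 3-hydroxyphenyl on a nitrogen on an aromatic ring gives a number 11.5 percentage points higher from compound 1 to compound 4 (beyond the scatter), a modest step but the first that can be read at this position. The earlier compounds shown here could not show this, as they differ from one another in more than one place. The step shows that, on the shared core, the hydrogen-bond donor and acceptor of the 3-hydroxyphenyl are not required for a high number, since the 4-fluorophenyl carries neither and the number still rises; nothing available explains that rise.

The compounds shown leave open which part of the change matters, as the hydroxyl is lost, a fluorine is gained and the substituent's place on the ring changes in one step, and a single pair cannot separate these. A plain phenyl with no substituent, or a chlorophenyl, would help to show whether the fluorine itself contributes, and because this read-out comes from one concentration, it leaves the potency of compound 1 and compound 4 open as well.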